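Compound 3 to compound 4: 4-bromophenyl for cyclohexyl

The source may report more compounds than this note shows. Statements on the series, on what has been measured and on what is new or still open speak of the compounds shown alone.

Compound 1 `N#Cc1ccc(CN[C@H]2[C@@H]3CN(c4ncc(C(=O)NO)cn4)C[C@@H]32)cc1`: 270 nM
Compound 2 `O=C(NO)c1cnc(N2C[C@@H]3[C@H](C2)[C@H]3NC(=O)c2ccccc2)nc1`: 5100 nM
Compound 3 `O=C(NO)c1cnc(N2C[C@@H]3[C@H](C2)[C@H]3NCC2CCCCC2)nc1`: 160 nM

These values come from a functional assay on HCT-116 cells (Homo sapiens) for antiproliferative activity, read by WST assay, with a stated time of 72 h; on this read-out lower numbers stand for stronger inhibition of growth and higher numbers for weaker inhibition of growth. Compound 3 reads 160 nM, the lowest number of the three, although the nearest comparison, a 1.7-fold lower number from compound 1 to compound 3 (0.23 log units; within the scatter), does not separate it from its neighbour. The furthest comparison is a 32-fold lower number from compound 2 to compound 3 (1.50 log units; beyond the scatter).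

The next compound is compound 4 `O=C(NO)c1cnc(N2C[C@@H]3[C@H](C2)[C@H]3NCc2ccc(Br)cc2)nc1`. The change is 4-bromophenyl in place of cyclohexyl on a saturated chain carbon bound to an amine nitrogen.

The most relevant evidence is a 1.7-fold lower number from compound 1 to compound 3 (0.23 log units; within the scatter). It exchanges 4-cyanophenyl and cyclohexyl at this same place, so it compares an aromatic and a non-aromatic six-membered ring directly. The large step, a 32-fold lower number from compound 2 to compound 3 (1.50 log units; beyond the scatter), bears less on the question, since it replaces benzoyl on the amine nitrogen, and compound 4 has no such carbonyl. Going by the values given here, with only one close comparison, and none carrying bromine, the data allow only a tentative reading. No change beyond the scatter is expected, with at most a slight drift upward toward compound 1.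

The expected change is a 1.3-fold higher number from compound 3 to compound 4 (0.10 log units; within the scatter). Compound 4 is estimated at 200 nM, with an expected range from 80 nM to 500 nM.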

Compound 4, concentration for 50% growth inhibition: 250 nM
Compound 4: middle estimate off by 1.3-fold (0.10 log units), on the low side, and the stated range covers the measured number.
By their numbers in this assay, from the lowest: compounds 3, 4 and 1 (each within the scatter of the next); then compound 2.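

In this assay, the step from cyclohexyl to 4-bromophenyl, a 1.6-fold higher number from compound 3 to compound 4 (0.19 log units; within the scatter), shows that this place accepts an aromatic ring carrying bromine as readily as a saturated ring, and the step of a 1.1-fold lower number from compound 1 to compound 4 (0.03 log units; within the scatter) shows that exchanging cyano for bromo on that aromatic ring also leaves the number within the scatter. The three compounds with a saturated chain carbon on the amine nitrogen therefore form one group, whichever of the three ring groups they carry, and the benzoyl compound stands apart from a second member of that group, a 20-fold lower number from compound 2 to compound 4 (1.31 log units; beyond the scatter), so its large gap is not tied to cyclohexylmethyl alone. No measurement shown here accounts for either the flat steps or the large one.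

As far as these compounds go, whether this tolerance extends to a carboxylic acid or an amine on the aromatic ring, or to a longer chain between the ring and the amine nitrogen, remains open. From the compounds shown here alone, it is equally open whether a benzoyl group bearing bromine would stay as far from 4-bromobenzyl as the unsubstituted benzoyl group does.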